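Cytotoxicity notes on the pyrazole nitrile series

The source may report more compounds than this note shows. Statements on the series, on what has been measured and on what is new or still open speak of the compounds shown alone.

Measured:
compound 1 `C[C@@H](Cn1ccc(-c2ccc(C#N)c(Cl)c2)n1)NC(=O)c1cccc(OCC(O)CO)c1` — > 30000 nM
compound 2 `C[C@@H](Cn1ccc(-c2ccc(C#N)c(Cl)c2)n1)NS(=O)(=O)c1cccnc1` — "not determined" (no result reported)

In an ADME assay on L02 cells (Homo sapiens) for cytotoxicity, read by CCK-8 assay, with a stated time of 6 days (on this read-out higher numbers stand for weaker inhibition and lower numbers for stronger inhibition), compound 1 reaches only a limit, > 30000 nM, and no number. For compound 2 this assay records "not determined" (no result reported), so compound 2 stands without any number. Compound 3 `Cc1ccnc(N[C@@H](C)Cn2ccc(-c3ccc(C#N)c(Cl)c3)n2)n1` differs from compound 2 by 4-methylpyrimidin-2-yl in place of (pyridin-3-yl)sulfonyl on an amine nitrogen. Going by the values given here, with no measured step to go by, the expected movement in this assay is none beyond the scatter, given that the limit of > 30000 nM in this assay, at which 1 of the 2 values shown sits, is the one point the series offers. Compound 3 is therefore expected near 30000 nM, between 10000 nM and 100000 nM, most likely as a limit.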

Compound 3, half-maximal inhibitory concentration: > 30000 nM
Compound 3 was reported as a limit (the forecaster's own chance of this, stated with the estimate: 70%); the middle value lies on the limit itself.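

In this assay compound 3 gives > 30000 nM, a limit and not a number. Going by these compounds alone, compound 2 has no number either, so no step between compound 2 and compound 3 can be read. What remains open is a numerical value for any of the three compounds, as the series offers only this: the limit of > 30000 nM in this assay, at which 2 of the 3 values shown sit.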